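This account rests on a few compounds, and the source may have more. Where it says the series, first, only, none or still open, it means among the compounds named here.

Compound 1 `Cc1cc(C)c(S(=O)(=O)NCCN2CCC(C)CC2)c(C)c1`: 1900 nM
Compound 2 `CC1CCN(C2CCN(S(=O)(=O)c3cccnc3F)CC2)CC1`: > 5000 nM, a limit of the assay
Compound 3 `CC1CCN(C2CCN(S(=O)(=O)c3ccc(Cl)nc3)CC2)CC1`: 3700 nM

In a functional assay on DLD-1 cells (Homo sapiens) for antiproliferative activity, read by CellTiter-Glo, with a stated time of 72 h (on this read-out higher numbers stand for weaker inhibition and lower numbers for stronger inhibition), compound 1 gives 1900 nM. For compound 2 the assay reports only a limit, > 5000 nM. Compound 3 gives 3700 nM, the highest of the two actual numbers, and compound 1 sits within the scatter of it. Going by the values given here, the only measured change on the sulfonyl sulfur is an at least 1.3-fold lower number from compound 2 to compound 3 (0.13 log units; that floor lies within the scatter), which can only be bounded because of the limit of > 5000 nM in this assay, at which 1 of the 3 values shown sits.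

Compound 4 `CC1CCN(C2CCN(S(=O)(=O)c3ccc(Cl)cc3Cl)CC2)CC1` differs from compound 3 by 2,4-dichlorophenyl in place of 6-chloropyridin-3-yl on a sulfonyl sulfur. Among the compounds with values here, no measured step exchanges a ring with one hetero atom for a ring of carbon only at this place, so the measured steps give little guidance, and the one bounded step lies within the scatter. I therefore expect no step beyond the scatter, a 1.5-fold lower number from compound 3 to compound 4 (0.17 log units; within the scatter), in this assay. My estimate for compound 4 in this assay is 2500 nM, with a range from 800 nM to 8000 nM.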

Compound 4, half-maximal inhibitory concentration: 1 nM
Compound 4: middle estimate off by 2500-fold (3.40 log units), on the high side; the whole stated range lies above it.
By their numbers in this assay, from the lowest: compound 4; then compounds 1 and 3 (each within the scatter of the next). At a limit, above all of these: compound 2.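

In this assay, the group on the sulfonyl sulfur can carry a very large change, which the pyridine compounds alone did not show: 2,4-dichlorophenyl in place of 6-chloropyridin-3-yl gives a 3700-fold lower number from compound 3 to compound 4 (3.57 log units; beyond the scatter), with the rest of the molecule unchanged. Compound 2 is reported only as a limit of the assay, > 5000 nM, so it has no actual number. The other step, an at least 5000-fold lower number from compound 2 to compound 4 (3.69 log units; beyond the scatter), points the same way but can be read only as a floor: the limit of > 5000 nM in this assay, at which 1 of the 4 values shown sits.

This single change swaps a ring with one hetero atom for a ring of carbon only and also brings in a second chlorine, so the compounds shown cannot separate these two differences. On these data alone, whether a plain phenyl ring, or a ring carrying trifluoromethyl groups instead of the chlorines, would give a similar number stays open.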